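Amide variation on a nitrobenzofurazan thioether ester series

The source may hold more compounds than are shown below. What is called first, only, known or untested is meant among the compounds shown, and "the series" means these compounds.

Measured compounds:
compound 1 `COc1ccccc1NC(=O)CCC(=O)OCCCCCCSc1ccc([N+](=O)[O-])c2nonc12` — 280 nM
compound 2 `CN(C)CCCNC(=O)CCC(=O)OCCCCCCSc1ccc([N+](=O)[O-])c2nonc12` — 90 nM

Compound 2 has the lowest number of the two in an assay on isolated protein for inhibition of glutathione S-transferase Mu 2 (Homo sapiens), with a stated time of 10 min; on this read-out lower numbers stand for stronger inhibition and higher numbers for weaker inhibition; its nearest neighbour, compound 1, differs by a 3.1-fold lower number from compound 1 to compound 2 (0.49 log units; beyond the scatter). Compound 3 `O=C(CCC(=O)N1CCCCC1)OCCCCCCSc1ccc([N+](=O)[O-])c2nonc12` is not yet measured; it differs from compound 2 by piperidin-1-yl in place of (3-(dimethylamino)propyl)amino on a carbonyl carbon. For the measured compounds named here, the only step bearing on this position is a 3.1-fold lower number from compound 1 to compound 2 (0.49 log units; beyond the scatter), a modest shift between two unrelated groups on the same carbonyl. Compound 3 carries neither group, so the expectation is a modest rise toward the level of compound 1, a 2.2-fold higher number from compound 2 to compound 3 (0.35 log units; beyond the scatter). The estimate for compound 3 in this assay is 200 nM, expected within 70 nM to 600 nM.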

Compound 3, half-maximal inhibitory concentration: 110 nM
Estimate against measurement, compound 3: 1.8-fold (0.26 log units) above; measured number inside the range.
By their numbers in this assay, from the lowest: compounds 2 and 3 (each within the scatter of the next); then compound 1.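

In this assay, replacing the open chain on this carbonyl carbon with a ring gives a 1.2-fold higher number from compound 2 to compound 3 (0.09 log units; within the scatter), so among these compounds neither the amide hydrogen nor the (3-(dimethylamino)propyl)amino chain is needed to hold this level. Piperidin-1-yl in place of (2-methoxyphenyl)amino gives a 2.5-fold lower number from compound 1 to compound 3 (0.41 log units; beyond the scatter), which leaves compound 1 apart from the other two. Nothing available explains either step.

Still open, going by these compounds, is whether morpholine or piperazine in place of piperidine holds this level. A carboxylic acid on this carbonyl carbon is also untested here.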